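The compounds below may be only part of what the source reports. "The series", "measured", "known", "first", "only" and "open" are said of these compounds alone.

Compound 1, `CCN1CCN(c2ccc(C(=O)Nc3n[nH]c4cc(-c5c(F)cc(F)c(OC)c5F)ccc34)cc2)CC1`: in a functional assay on SNU-16 cells (Homo sapiens) for antiproliferative activity, read by CCK-8 assay, with a stated time of 72 h (a lower number here means a stronger inhibitor, a higher number a weaker inhibitor), compound 1 gives > 1000 nM, which is a limit of the assay rather than a number.
Compound 2, `CCN1CCN(c2ccc(C(=O)Nc3n[nH]c4cc(-c5cccc(OC)c5F)ccc34)cc2C(F)(F)F)CC1`: compound 2 gives > 1000 nM, again only a limit.
Compound 3, `COc1ccc(F)c(-c2ccc3c(NC(=O)c4ccc(N5CCN(C(C)=O)CC5)cc4)n[nH]c3c2)c1F`: compound 3 gives 322 nM.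

Compound 3 therefore holds the only actual number shown; the two other values sit at the limit of > 1000 nM in this assay, at which 2 of the 3 values shown sit. Compound 4, `COc1ccc(F)c(-c2ccc3c(NC(=O)c4ccc(N5C[C@@H](C)N[C@@H](C)C5)cc4)n[nH]c3c2)c1F`, differs from compound 3 in one place: 3,5-dimethylpiperazin-1-yl in place of 4-acetylpiperazin-1-yl on an aromatic carbon. Among the compounds with values here, no two measured compounds differ in a single place, so no measured step guides the size of this change. Compound 4 is nonetheless expected to be somewhat stronger than compound 3, with an estimate of 80 nM, in a range from 15 nM to 500 nM. That estimate means a 4.0-fold lower number from compound 3 to compound 4 (0.60 log units; beyond the scatter).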

Compound 4, half-maximal inhibitory concentration: 582 nM
Compound 4: middle estimate off by 7.3-fold (0.86 log units), on the low side, outside the stated range (above it).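

At this aromatic carbon, 3,5-dimethylpiperazin-1-yl in place of 4-acetylpiperazin-1-yl gives a 1.8-fold higher number from compound 3 to compound 4 (0.26 log units; within the scatter) in this assay. The two groups therefore cannot be told apart in this assay, although the entering group adds a hydrogen-bond donor and two defined stereocentres. Nothing shown accounts for this closeness.

Going by these compounds, whether a morpholine ring or an open-chain amine at this carbon would read differently stays open. So does what a piperazine without the two methyl groups would give.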